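Tolerance of a Cyclic Urea Series in a Cytotoxicity Assay

The source may hold more compounds than are shown below. What is called first, only, known or untested is meant among the compounds shown, and "the series" means these compounds.

Measured compounds:
Compound 1, `O=C1N(CCCCCCOc2ccc(C(F)(F)F)cc2)CCN1c1ccncn1`: > 25000 nM
Compound 2, `O=C1N(CCCCCCOc2ccc(Cl)cc2)CCN1c1ccncn1`: > 25000 nM
Compound 3, `O=C1N(CCCCCCOc2ccc(Cl)cc2)CCN1c1ccccc1`: > 25000 nM

All three compounds were tested in a functional assay on cells (Homo sapiens) for cytotoxicity; a higher number here means that more compound is tolerated, a lower number that less compound is tolerated. In this assay compound 1 reaches only a limit, > 25000 nM. Compound 2 likewise reaches only a limit, > 25000 nM. Compound 3 also gives only a limit, > 25000 nM. Because of the limit of > 25000 nM in this assay, at which 3 of the 3 values shown sit, none of the steps between them can be read as a number.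

Compound 1 differs from compound 2 by trifluoromethyl in place of chloro on an aromatic carbon, and the step that the two limits leave unreadable from compound 2 to compound 1 is left unreadable by the two limits. Compound 3 differs from compound 2 in its core, (phenyl in place of pyrimidin-4-yl on an amide-type nitrogen in a ring), and the step that the two limits leave unreadable from compound 2 to compound 3 is likewise unreadable.

The unmeasured compound 4, `O=C1N(CCCCCCOc2ccc(C(F)(F)F)cc2)CCN1c1ccccc1`, differs from compound 3 by trifluoromethyl in place of chloro on an aromatic carbon. This is the same change as that from compound 2 to compound 1, placed identically. Since compound 2 and compound 1 both sit at the limit, compound 3 is expected to carry the same change with no readable effect, and the expected step is a step that the limit leaves unreadable from compound 3 to compound 4. Compound 4 is therefore expected to give 30000 nM, with a range from 15000 nM to 100000 nM, most likely again reported only as a limit.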

Compound 4, half-maximal cytotoxic concentration: > 25000 nM
Compound 4 gave a limit, no number; the forecaster's own chance of this, stated with the estimate: 85%; the middle value does not contradict the limit.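

In this assay compound 4 gives only a limit, > 25000 nM. No step from compound 3 to compound 4 or from compound 1 to compound 4 can be read, because all the values share one limit: the limit of > 25000 nM in this assay, at which 4 of the 4 values shown sit.

The compounds shown leave open at what concentration, if any, each becomes cytotoxic, and whether either change, trifluoromethyl in place of chloro or phenyl in place of pyrimidin-4-yl, alters tolerance at all.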